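The source may report more compounds than this note shows. Statements on the series, on what has been measured and on what is new or still open speak of the compounds shown alone.

Measured compounds in this study:
compound 1, `CO[C@@H]1C[C@@H]2O[C@@]2(C)C(=O)N(C)[C@@H](C(C)C)C(=O)N[C@H](Cc2cc(Cl)c(O)c(Cl)c2)C(=O)N[C@@H](C(C)(C)O)C(=O)O[C@H](c2ccccc2)[C@H](C)/C=C/C=C/1C`, 3.5 nM
compound 2, `CC[C@H](C)[C@H]1C(=O)N[C@H](Cc2cc(Cl)c(O)c(Cl)c2)C(=O)N[C@@H](C(C)(C)O)C(=O)O[C@H](c2ccccc2)[C@H](C)/C=C/C=C(\C)[C@H](OC)C/C=C/C(=O)N1C`, 40.5 nM
compound 3, `CC[C@H](C)[C@H]1C(=O)N[C@H](Cc2cc(Cl)c(O)c(Cl)c2)C(=O)N[C@@H](C(C)(C)O)C(=O)O[C@H](c2ccccc2)[C@H](C)/C=C/C=C(\C)[C@H](OC)C/C=C(\C)C(=O)N1C`, 10.1 nM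

In a functional assay on A549 cells (Homo sapiens) for antiproliferative activity, read by MTT assay, with a stated time of 72 h (on this read-out higher numbers stand for weaker inhibition and lower numbers for stronger inhibition), compound 1 gives the lowest number of the three. Compound 3 stands nearest to it, beyond the scatter, and compound 2 furthest, also beyond the scatter. Compound 4, `CC[C@H](C)[C@H]1C(=O)N[C@H](Cc2cc(Cl)c(O)c(Cl)c2)C(=O)N[C@@H](C(C)(C)O)C(=O)O[C@H](c2ccccc2)[C@H](C)/C=C/C=C(\C)[C@H](OC)C[C@@H]2O[C@@]2(C)C(=O)N1C`, is not yet measured. It differs from compound 1 by methyl in place of hydrogen on a saturated chain carbon, two bonds along the chain from a saturated ring carbon. For the measured compounds named here, no two measured compounds are separated by this change alone, so its size cannot be read directly; compound 2 and compound 3 carry the sec-butyl already, but with other differences from compound 1. The step from compound 1 to compound 4 is expected to be small, a 1.2-fold lower number from compound 1 to compound 4 (0.07 log units; within the scatter), none beyond the scatter. Compound 4 is expected to give 3 nM in this assay, in a range from 1.2 nM to 8 nM.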

Compound 4, half-maximal inhibitory concentration: 13.1 nM
For compound 4 the middle estimate is 4.4-fold (0.64 log units) below the measured one; the measured number lies above the stated range.
By their numbers in this assay, from the lowest: compound 1; then compounds 3 and 4 (each within the scatter of the next); then compound 2.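

In this assay, the change from isopropyl to sec-butyl can now be read on its own: the added methyl gives a 3.7-fold higher number from compound 1 to compound 4 (0.57 log units; beyond the scatter) and so weakens inhibition by a modest step. This position is therefore not indifferent to one extra carbon on the saturated chain, which compound 2 and compound 3 could not show, as they differ from compound 1 in other ways too. Nothing available accounts for this step. As far as these compounds go, whether a longer chain such as n-pentyl, or a hydroxyl group at this place, would give a similar step remains open. So does whether the step carries over to other cell lines.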